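The compounds below may be only part of what the source reports. "The series", "measured", "known", "first", "only" and "open" are said of these compounds alone.

Measured so far in an assay on a protein complex for inhibition of CDK8/Cyclin C (Homo sapiens), with a stated time of 1 h; a lower number here means a stronger inhibitor, a higher number a weaker inhibitor:
compound 1 `NNC(=O)CCc1ccncc1-c1ccc2ccccc2c1`: 7.7 nM
compound 2 `CNC(=O)CCc1ccncc1-c1ccc2ccccc2c1`: 21.1 nM
compound 3 `O=C(/C=C/c1ccncc1-c1ccc2ccccc2c1)NC1CC1`: 40.1 nM

Compound 3 carries the highest of the three numbers. The step of a 1.9-fold higher number from compound 2 to compound 3 (0.28 log units; within the scatter) lies within the scatter; the step of a 5.2-fold higher number from compound 1 to compound 3 (0.72 log units; beyond the scatter) lies beyond it. All three compounds share one core and differ only in the side chain.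

Compound 4 `COC(=O)CCc1ccncc1-c1ccc2ccccc2c1` has not been measured in this assay. The change from compound 3 is 2-(methoxycarbonyl)ethyl in place of 2-(cyclopropylcarbamoyl)ethenyl on an aromatic carbon. For the measured compounds named here, two measured steps touch this region. Exchanging the substituent on the amide-type nitrogen gave a 2.7-fold higher number from compound 1 to compound 2 (0.44 log units; beyond the scatter), and exchanging the whole side chain gave a 1.9-fold higher number from compound 2 to compound 3 (0.28 log units; within the scatter). Neither of these goes as far as the 2-(methoxycarbonyl)ethyl group of compound 4, which is further from every measured compound than they are from each other. Changes to the side chain so far cost modestly or stayed within the scatter, so a modest rise in this assay is expected, a 2.7-fold higher number from compound 3 to compound 4 (0.44 log units; beyond the scatter), with wide uncertainty. Compound 4 is expected at 110 nM, in the range 30 nM to 450 nM.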

Compound 4, half-maximal inhibitory concentration: 259 nM
Compound 4: the middle estimate sits 2.4-fold (0.37 log units) below what was measured; the measured number falls inside the stated range.
By their numbers in this assay, from the lowest: compound 1; then compounds 2 and 3 (each within the scatter of the next); then compound 4.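

In this assay, methoxy in place of methylamino on the carbonyl carbon gives a 12-fold higher number from compound 2 to compound 4 (1.09 log units; beyond the scatter) and counts as large, and methoxy in place of aminoamino gives a 34-fold higher number from compound 1 to compound 4 (1.53 log units; beyond the scatter) and is larger still. The wider exchange of the side chain gives a 6.5-fold higher number from compound 3 to compound 4 (0.81 log units; beyond the scatter) and so leaves compound 4 apart from all three compounds with an amide-type nitrogen on this carbonyl, the first clear separation on this aromatic carbon opposite the ring nitrogen. No available evidence accounts for this separation.

Compound 4 alone cannot separate the loss of the amide hydrogen from the presence of the methoxy group. A carboxylic acid or a dimethylamide on the same chain would bear on that question, and a longer chain would test how much room the series has.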